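Fluoro for Chloro on a Weak Receptor Agonist Core

This account rests on a few compounds, and the source may have more. Where it says the series, first, only, none or still open, it means among the compounds named here.

Compound 1, `CCCCCn1c(N)nc2c(C)cccc21`: 1800 nM
Compound 2, `CCCCCNc1nc(N)nc(C)c1I`: 3700 nM
Compound 3, `CCCCNc1nc(N)nc(C)c1Cl`: 20000 nM

In an assay on HEK293 cells for agonist activity at Toll-like receptor 8 (Homo sapiens), read by reporter gene assay (a higher number here means that more compound is needed for the effect, a lower number that less compound is needed), compound 3 gives 20000 nM, the highest of the three numbers; compound 2 sits lower, beyond the scatter, and compound 1 lower still, also beyond the scatter. Compound 4, `CCCCNc1nc(N)nc(C)c1F`, differs from compound 3 in one place: fluoro in place of chloro on an aromatic carbon. Among the compounds with values here, no measured pair shows this change alone, so its size is open. On the numbers shown, compound 3 already sits at the weak end, and the step to compound 4 is expected to be a 1.5-fold higher number from compound 3 to compound 4 (0.18 log units; within the scatter), a modest rise that could also be none beyond the scatter. Compound 4 is therefore estimated at 30000 nM, with a range from 8000 nM to 100000 nM.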

Compound 4, half-maximal effective concentration: 34000 nM
Compound 4: the middle estimate sits 1.1-fold (0.05 log units) below what was measured; low and high end bracket the measured number.
By their numbers in this assay, from the lowest: compound 1; then compound 2; then compounds 3 and 4 (each within the scatter of the next).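

In this assay, fluoro in place of chloro on this aromatic carbon comes out as a 1.7-fold higher number from compound 3 to compound 4 (0.23 log units; within the scatter) and so does not separate the two halogens. Within the data shown here, this is the first pair here to differ in one place, and it shows that this exchange alone leaves the number within the scatter.

Going by these compounds, whether a nitrile, a methoxy group or plain hydrogen at this carbon would move the number beyond the scatter stays open, as does what a longer chain would do with fluoro in place. No measurement at hand explains the result.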